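Swapping the Aminohydroxy Side Chain for a Butyl Chain

The compounds below may be only part of what the source reports. "The series", "measured", "known", "first", "only" and "open" are said of these compounds alone.

Compound 1 `[N-]=[N+]=NCC(O)Cn1c(=O)n(C2OC(CO)[C@@H](O)[C@H]2O)c2nc(N)nc(O)c21` gives 91% in a functional assay on the whole organism (B cells) with Mus musculus as the target; on this read-out lower numbers stand for smaller maximal responses and higher numbers for larger maximal responses.
Compound 2 `CCOC(=O)Cn1c(=O)n(C2OC(CO)[C@@H](O)[C@H]2O)c2nc(N)nc(O)c21` gives 86% in this assay.
Compound 3 `NCC(O)Cn1c(=O)n(C2OC(CO)[C@@H](O)[C@H]2O)c2nc(N)nc(O)c21` gives 110% in this assay.

Compound 3 stands highest of the three in this assay, and both steps leading to it lie beyond the scatter: a number 19 percentage points higher from compound 1 to compound 3 (beyond the scatter) and a number 24 percentage points higher from compound 2 to compound 3 (beyond the scatter). The other pair is flat, since a number 5 percentage points lower from compound 1 to compound 2 (within the scatter).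

Compound 4 `CCCCn1c(=O)n(C2OC(CO)[C@@H](O)[C@H]2O)c2nc(N)nc(O)c21` is not yet measured. The change from compound 3 is propyl in place of 2-amino-1-hydroxyethyl on a saturated chain carbon bound to an aromatic nitrogen. The group that leaves carries two hydrogen-bond donors and two hydrogen-bond acceptors; the propyl that enters carries none. The two steps that bear on this are those into compound 3, where the azido and the ethoxycarbonyl, each with fewer donors, gave modestly lower responses. Compound 4 goes further in the same direction, so a modest drop beyond the scatter is expected, with compound 4 estimated at a number 22 percentage points lower from compound 3 to compound 4 (beyond the scatter). Compound 4 is therefore expected to give about 88% in this assay, most likely between 72% and 104%.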

Compound 4, largest response reached (reported as maximal response), in percent of the reference or control that the assay uses: 86%
Beside the measured number, compound 4's estimate is 2 percentage points above it; the measured number falls inside the stated range.
By their numbers in this assay, from the lowest: compounds 2, 4 and 1 (each within the scatter of the next); then compound 3.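

In this assay, propyl in place of 2-amino-1-hydroxyethyl on a saturated chain carbon bound to an aromatic nitrogen gives a number 24 percentage points lower from compound 3 to compound 4 (beyond the scatter), so a side chain with no hydrogen-bond donors or acceptors falls in with the azido and ethoxycarbonyl compounds. The steps of no change at the digits printed from compound 2 to compound 4 (within the scatter) and a number 5 percentage points lower from compound 1 to compound 4 (within the scatter) show no further fall, so among these compounds the response does not keep dropping as donors are lost, and only the amino-bearing chain of compound 3 stands apart. No measurement at hand explains this difference.

The compounds shown leave open whether the amine alone accounts for the higher response of compound 3, or whether it needs the neighbouring hydroxyl. A simple aminoalkyl chain without the hydroxyl and a diol chain with a hydroxyl in place of the amine would separate the two.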